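Chloro to bromo on the 4-chlorobenzyl group

The source may hold more compounds than are shown below. What is called first, only, known or untested is meant among the compounds shown, and "the series" means these compounds.

In a functional assay on MDA-MB-231 cells (Homo sapiens) for inhibition (a higher number here means a weaker inhibitor, a lower number a stronger inhibitor), compound 1 `COC(=O)C(C(=O)OC)C1CC(=O)C=CC12OCC(=O)N2Cc1ccc(C)cc1` gives 340 nM and compound 2 `COC(=O)C(C(=O)OC)C1CC(=O)C=CC12OCC(=O)N2Cc1ccc(Cl)cc1` gives 380 nM, so the two values lie within the scatter of each other. Compound 3 `COC(=O)C(C(=O)OC)C1CC(=O)C=CC12OCC(=O)N2Cc1ccc(Br)cc1` differs from compound 2 by a single change, bromo in place of chloro on an aromatic carbon, para to a large group, turning 4-chlorobenzyl into 4-bromobenzyl. Within the data shown here, only one measured step bears on this change, a 1.1-fold higher number from compound 1 to compound 2 (0.05 log units; within the scatter), chloro in place of methyl on the same aromatic carbon. Among the measured compounds shown here, no bromo compound has been measured yet, so the evidence is thin. Because a 1.1-fold higher number from compound 1 to compound 2 (0.05 log units; within the scatter) stayed within the scatter, no shift beyond the scatter is expected in this assay. The expected step is a 1.0-fold lower number from compound 2 to compound 3 (0.01 log units; within the scatter). For compound 3 the estimated value is 370 nM, with an expected range of 190 nM to 720 nM.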

Compound 3, half-maximal inhibitory concentration: 1230 nM
Compound 3: middle estimate off by 3.3-fold (0.52 log units), on the low side; measured number outside the range, above it.
By their numbers in this assay, from the lowest: compounds 1 and 2 (each within the scatter of the next); then compound 3.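

In this assay this aromatic carbon, para to a large group, proves sensitive to the exchange of one halogen for the other: the change from 4-chlorobenzyl to 4-bromobenzyl gives a 3.2-fold higher number from compound 2 to compound 3 (0.51 log units; beyond the scatter), whereas the earlier pair had shown only a 1.1-fold higher number from compound 1 to compound 2 (0.05 log units; within the scatter) and gave no sign of this sensitivity. The shift also holds against the methyl group, with a 3.6-fold higher number from compound 1 to compound 3 (0.56 log units; beyond the scatter), so compound 3 separates from both compound 1 and compound 2, which stay within the scatter of each other. Nothing among the data shown accounts for the loss on going to bromo.

Open, on these data alone, is whether a methoxy group, an amine or a carboxylic acid on this aromatic carbon would sit with compound 1 and compound 2 or with compound 3. Also open, as far as these compounds go, is whether chloro to bromo would give a similar step with a carboxylic acid in place of the two methyl esters.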